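Chain-end replacement on compound 1: nitrile to methyltetrazole

The source may hold more compounds than are shown below. What is called first, only, known or untested is meant among the compounds shown, and "the series" means these compounds.

Compound 1 `CCc1cc(C(C)=O)c(O)cc1OCCCCCCC(C)(C)C#N` is the reference point of this pair of notes. Within the data shown here, in an assay on isolated protein for binding affinity to leukotriene B4 receptor 1 (Homo sapiens), tested at 1 uM (a lower number here means less inhibition, a higher number more inhibition at the concentration tested (going by the name of the read-out)), compound 1 gives 30%, the lowest of the two numbers so far. Among the measured compounds shown here, compound 2 `CCc1cc(C(C)=O)c(O)cc1OCCCC(C)(C)C(=O)O` gives 43% in this assay, and the only measured step is a number 13 percentage points higher from compound 1 to compound 2 (beyond the scatter), where 1-carboxy-1-methylethyl replaces 4-cyano-4-methylpentyl on a saturated chain carbon, three bonds along the chain from an oxygen on an aromatic ring. Compound 3 `CCc1cc(C(C)=O)c(O)cc1OCCCCCC(C)(C)c1nnnn1C` is not yet measured. Its change from compound 1 is 1-methyl-1-(1-methyl-1H-tetrazol-5-yl)ethyl in place of 2-cyano-2-methylpropyl on a saturated chain carbon, five bonds along the chain from an oxygen on an aromatic ring. For the measured compounds named here, only the step from compound 1 to compound 2 bears on it: both alter what ends the chain that leaves the shared core, and that step was modest and upward. In compound 3 the nitrile gives way to a ring rather than to an acid, so the measured step is only a loose guide. Compound 3 is therefore expected to show a number 8 percentage points higher from compound 1 to compound 3 (within the scatter), a small rise or none beyond the scatter. Compound 3 is estimated at 38% in this assay, with a range from 20% to 56%.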

Compound 3, a percentage reported as inhibition, at one concentration (the size of the read-out at that concentration, not a potency): 59%
Compound 3: the middle estimate sits 21 percentage points below what was measured; the measured number lies above the stated range.
By their numbers in this assay, from the lowest: compound 1; then compound 2; then compound 3.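

In this assay the replacement gives a number 29 percentage points higher from compound 1 to compound 3 (beyond the scatter), so this chain end accepts a five-membered aromatic ring with 4 hetero atoms in place of the nitrile-bearing 2-cyano-2-methylpropyl, and the number rises rather than falls. The earlier step to compound 2 brought in a carboxy group, whereas the 1-methyl-1-(1-methyl-1H-tetrazol-5-yl)ethyl group of compound 3 has 0 hydrogen-bond donors and no net charge, so a rise at this chain end in this series does not require a carboxy group. No measurement on these groups bears on the result, and the rise remains without an explanation.

Still open, as far as these compounds go, is whether the rise belongs to the tetrazole ring itself or to the methyl on it, which an unsubstituted tetrazole at the same chain end would help to separate. In both steps shown, the chain and its end group change together, so the contribution of chain length cannot be read, and a pair differing only by a longer chain ending in the same methyltetrazole would address that.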